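Urea in Place of Pyridine Amide: Compound 4 Expected

The source may hold more compounds than are shown below. What is called first, only, known or untested is meant among the compounds shown, and "the series" means these compounds.

The measured compounds:
compound 1, `Cc1cc(CNc2nc3cc(Cl)c(Cl)cc3[nH]2)ncc1-c1cn(C)nc1C`, giving 0.43 nM;
compound 2, `Cc1cc(CNC(=O)c2cc3c(Cl)cc(Cl)cc3[nH]2)ncc1-c1cn(C)nc1C`, giving 0.61 nM;
compound 3, `Cc1cc(CNC(=O)c2cc(Cl)nc(Cl)c2)ncc1-c1cn(C)nc1C`, giving > 100 nM.

In a functional assay on CHO cells for antagonist activity at sphingosine 1-phosphate receptor 2 (Homo sapiens), read by scintillation counting and GTPgammaS binding, with a stated time of 4 h, in the presence of a further agent that is not named here (a higher number here means a weaker inhibitor, a lower number a stronger inhibitor), compound 1 gives 0.43 nM and compound 2 gives 0.61 nM. Within the data shown here, for compound 3 this assay reports only a limit, > 100 nM, and it sits at the limit of > 100 nM in this assay, at which 1 of the 3 values shown sits, so no number and no counted step separates compound 3 from the other two. Compound 4, `Cc1cc(CNC(=O)Nc2cc(Cl)cc(Cl)c2)ncc1-c1cn(C)nc1C`, differs from compound 3 by (3,5-dichlorophenyl)amino in place of 2,6-dichloropyridin-4-yl on a carbonyl carbon. Among the measured compounds shown here, no measured pair shows this change, so any expectation is loose. Compound 4 is expected to be a stronger inhibitor than the limit of compound 3, a step of an at least 3.3-fold lower number from compound 3 to compound 4 (0.52 log units; beyond the scatter), and its value in this assay is estimated at 30 nM, within 3 nM to 300 nM.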

Compound 4, half-maximal inhibitory concentration: 0.3 nM
Compound 4: middle estimate off by 100-fold (2.00 log units), on the high side, and the stated range ends above it.
By their numbers in this assay, from the lowest: compounds 4, 1 and 2 (each within the scatter of the next, the first and the last beyond it). At a limit, above all of these: compound 3.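

On a carbonyl carbon whose other neighbour is an amide-type nitrogen, (3,5-dichlorophenyl)amino in place of 2,6-dichloropyridin-4-yl gives, in this assay, an at least 330-fold lower number from compound 3 to compound 4 (2.52 log units; beyond the scatter). Thus a single dichlorinated six-membered aromatic ring on this carbonyl is not itself disqualifying, as compound 4 gives 0.3 nM. The value of compound 3 is a limit, not a number: the limit of > 100 nM in this assay, at which 1 of the 4 values shown sits.

The compounds shown do not separate the entering nitrogen from the loss of the ring nitrogen. Going by these compounds, whether a methylene could replace that entering nitrogen, or fluorine the chlorines, also stays open.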